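The compounds below may be only part of what the source reports. "The series", "measured", "known", "first", "only" and "open" are said of these compounds alone.

Compound 1: `CCC1C(=O)N(C)c2cnc(-n3ccc4cc(C(N)=O)ccc43)nc2N1c1ccn(C)n1` — reported as "not active" (no number reported) in a functional assay on NCI-H1975 cells (Homo sapiens) for antiproliferative activity, read by CCK-8 assay, with a stated time of 72 h (on this read-out higher numbers stand for weaker inhibition of growth and lower numbers for stronger inhibition of growth), with no number given.
Compound 2: `CC[C@@H]1C(=O)N(C)c2cnc(Nc3ccc(S(=O)(=O)NCCO)cc3)nc2N1C1CCCC1` — 2100 nM in this assay.

Compound 1 has no single number on which to place it; the only thing known is that it showed no activity in this assay, while compound 2 in this assay gives 2100 nM. Compound 3 is `CCC1C(=O)N(C)c2cnc(-n3ccc4cc(F)ccc43)nc2N1c1ccn(C)n1`. It differs from compound 1 in one place: fluoro in place of carbamoyl on an aromatic carbon. For the measured compounds named here, no measured pair shows what this change does, so there is no measured step to lean on. Since compound 1 was not active, the expectation for compound 3 is for weak growth inhibition as well, with a fair chance that this assay again reports only a limit rather than a number. The estimate for compound 3 in this assay is 6000 nM, within a range from 1500 nM to 30000 nM.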

Compound 3, concentration for 50% growth inhibition: 28600 nM
Compound 3: the middle estimate sits 4.8-fold (0.68 log units) below what was measured; low and high end bracket the measured number.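

For the compounds shown here, compound 1 has no number in this assay and compound 3 gives 28600 nM there, so no step between them can be read. The compounds shown leave open how far fluoro in place of carbamoyl shifts growth inhibition. No measurement shown helps explain this result.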